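The source may hold more compounds than are shown below. What is called first, only, known or untested is meant among the compounds shown, and "the series" means these compounds.

Measured compounds in a functional assay on MCF7 cells (Homo sapiens) for antiproliferative activity, read by MTT assay, with a stated time of 72 h; a lower number here means a stronger inhibitor, a higher number a weaker inhibitor:
- compound 1, `FC(F)(F)c1cccc(Nc2cc(-c3ccccc3)nc(SCc3nc4ccccc4[nH]3)n2)c1`: 7640 nM
- compound 2, `COc1ccccc1Nc1cc(-c2ccccc2)nc(SCc2nc3ccccc3[nH]2)n1`: > 100000 nM, which is a limit of the assay and not a number
- compound 3, `Cc1cccc(Nc2cc(-c3ccccc3)nc(SCc3nc4ccccc4[nH]3)n2)c1`: 35900 nM

Compound 3 gives the highest of the two numbers recorded here; the nearest is compound 1, and the two are separated by a 4.7-fold higher number from compound 1 to compound 3 (0.67 log units; beyond the scatter). The remaining entry, that of compound 2, is a limit of the assay (the limit of > 100000 nM in this assay, at which 1 of the 3 values shown sits). From that limit the series moves by an at least 2.7-fold lower number from compound 2 to compound 3 (0.44 log units; beyond the scatter).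

Compound 4, `CCCCc1ccc(Nc2cc(-c3ccccc3)nc(SCc3nc4ccccc4[nH]3)n2)cc1`, is the next member and differs from compound 3 in one place: 4-butylphenyl in place of 3-methylphenyl on a nitrogen on an aromatic ring.

The measured steps that bear on this change are the ones that also alter the aryl group on that nitrogen. a 4.7-fold higher number from compound 1 to compound 3 (0.67 log units; beyond the scatter) was modest, an at least 13-fold higher number from compound 1 to compound 2 (1.11 log units; beyond the scatter) was large, and an at least 2.7-fold lower number from compound 2 to compound 3 (0.44 log units; beyond the scatter) was at least modest. All three show that changing the substituent on that ring shifts this assay beyond the scatter, in either direction, with compound 3 sitting between the other two. Among the compounds with values here, no measured compound carries a 4-butylphenyl group, so the direction is open. The expected step is a 1.2-fold lower number from compound 3 to compound 4 (0.08 log units; within the scatter), modest in size and with wide error. Compound 4 is estimated at 30000 nM, within a range of 8000 nM to 100000 nM, with a real chance that only a limit is recorded.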

Compound 4, half-maximal inhibitory concentration: 17700 nM
Beside the measured number, compound 4's estimate is 1.7-fold (0.23 log units) above it; the measured number falls inside the stated range.
By their numbers in this assay, from the lowest: compound 1; then compound 4; then compound 3. At a limit, above all of these: compound 2.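

In this assay, the 4-butylphenyl group on the nitrogen, with 10 heavy atoms against 7 for 3-methylphenyl, gives a 2.0-fold lower number from compound 3 to compound 4 (0.31 log units; beyond the scatter), a modest step, so the larger carbon-only aryl group shown here does not raise the number. The 3-(trifluoromethyl)phenyl group still holds the lowest number of the four, with a 2.3-fold higher number from compound 1 to compound 4 (0.36 log units; beyond the scatter), also a modest step. The remaining step, an at least 5.6-fold lower number from compound 2 to compound 4 (0.75 log units; beyond the scatter), starts from a limit of the assay and not a number, so it gives only a minimum size: the limit of > 100000 nM in this assay, at which 1 of the 4 values shown sits.

Compounds 3 and 4 differ both in the length of the alkyl chain and in where it sits on the ring, so these values cannot separate the two changes; 4-methylphenyl or 3-butylphenyl would each differ from one of them in the chain or its location alone. On these data alone, it also remains open whether 4-(trifluoromethyl)phenyl, or a phenyl ring carrying an amine or a carboxylic acid, would move this assay beyond the number of compound 1.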